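The source may report more compounds than this note shows. Statements on the series, on what has been measured and on what is new or still open speak of the compounds shown alone.

Compound 1 `O=C1OC[C@H](Cc2ccccc2O)[C@H]1Cc1ccc(Cl)c(Cl)c1`: 33000 nM
Compound 2 `COc1cccc(C[C@H]2COC(=O)[C@@H]2Cc2ccc(Cl)c(Cl)c2)c1`: 34000 nM

In a functional assay on HL-60 cells (Homo sapiens) for cytotoxicity, read by WST assay, with a stated time of 48 h (a higher number here means that more compound is needed for the effect, a lower number that less compound is needed), compound 2 gives 34000 nM and stands level with compound 1, since the two values lie within the scatter of each other. The next compound to be tested is compound 3 `O=C1OC[C@H](Cc2ccc(O)cc2)[C@H]1Cc1ccc(Cl)c(Cl)c1`, which has not yet been measured. It differs from compound 2 as follows: 4-hydroxyphenyl in place of 3-methoxyphenyl on a saturated chain carbon bound to a saturated ring carbon. In words, 4-hydroxyphenyl stands in place of 3-methoxyphenyl on a saturated chain carbon bound to a saturated ring carbon.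

Among the compounds with values here, only one measured step bears on this change: a 1.0-fold higher number from compound 1 to compound 2 (0.01 log units; within the scatter). That step exchanged 2-hydroxyphenyl for 3-methoxyphenyl at the same place and stayed within the scatter. Within the data shown here, no measured compound carries 4-hydroxyphenyl, so this single step is a thin guide. Going by that step, no change beyond the scatter is expected in this assay. The expected step is a 1.1-fold lower number from compound 2 to compound 3 (0.05 log units; within the scatter). For compound 3 the estimated value is 30000 nM, with an expected range from 13000 nM to 70000 nM.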

Compound 3, half-maximal effective concentration: 37000 nM
Beside the measured number, compound 3's estimate is 1.2-fold (0.09 log units) below it; measured number inside the range.
By their numbers in this assay, from the lowest: compounds 1, 2 and 3 (each within the scatter of the next).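

In this assay, 4-hydroxyphenyl on a saturated chain carbon bound to a saturated ring carbon stands level with both groups seen there before: the comparison with 3-methoxyphenyl gives a 1.1-fold higher number from compound 2 to compound 3 (0.04 log units; within the scatter), and the comparison with 2-hydroxyphenyl gives a 1.1-fold higher number from compound 1 to compound 3 (0.05 log units; within the scatter). The earlier pair had only set 2-hydroxyphenyl against 3-methoxyphenyl, so the new result adds a third substituted phenyl group at this place and a direct comparison of the two hydroxyphenyl groups, and none of the three stands apart from the others in this assay. The exchange of 3-methoxyphenyl, with no hydrogen-bond donor, for 4-hydroxyphenyl, with one, also comes without a step beyond the scatter, and nothing available explains why these compounds read alike.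

What the three compounds leave open is whether any group at this place can move the number beyond the scatter, since a phenyl ring carrying an amine or a carboxylic acid, or a longer chain between the phenyl ring and the shared core, does not appear among them. All three also share the rest of the core, so they say nothing about how the reading depends on any other part of the molecule.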